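Removing a methyl from an oxygen in a cytotoxicity series

A few compounds are considered here, and "the series" means these few. Any claim that something is new, unique, unknown or untested is made for them only; others in the source may bear on it.

Of the compounds shown here, two have been measured in a functional assay on SF-295 cells (Homo sapiens) for cytotoxicity, read by sulforhodamine B assay, with a stated time of 48 h, tested at 1 uM; on this read-out lower numbers stand for a stronger effect and higher numbers for a weaker effect at the one concentration tested. Compound 1, `Cc1cc(O)cc(-c2nn(CC#N)cc2-c2ccnc(-c3ccc(Oc4ccccc4)cc3)c2)c1`, gives 30% in this assay. Compound 2, `COc1cc(C)cc(-c2nn(CC#N)cc2-c2ccnc(-c3ccc(N(C)C)cc3)c2)c1`, gives -7% in this assay, the lower of the two numbers, and the gap to compound 1 is beyond the scatter. Compound 2 and compound 1 differ in two places at once, so no single change can be read from that gap.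

Compound 3, `Cc1cc(O)cc(-c2nn(CC#N)cc2-c2ccnc(-c3ccc(N(C)C)cc3)c2)c1`, differs from compound 2 in one place only: hydrogen in place of methyl on an oxygen on an aromatic ring. Going by the values given here, no measured pair shows this change on its own. Compound 1 carries the same hydroxy group yet also a different group elsewhere, so it offers no clean guide.

For compound 3 a small step is expected, a number 12 percentage points higher from compound 2 to compound 3 (beyond the scatter), likely within the scatter. Compound 3 is therefore estimated at 5% in this assay, with a range from -15% to 30%.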

Compound 3, a percentage reported as activity, at one concentration (the size of the read-out at that concentration, not a potency): -5%
Estimate against measurement, compound 3: 10 percentage points above; measured number inside the range.
By their numbers in this assay, from the lowest: compounds 2 and 3 (each within the scatter of the next); then compound 1.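

In this assay, hydrogen in place of methyl on an oxygen on an aromatic ring gives a number 2 percentage points higher from compound 2 to compound 3 (within the scatter), so with the dimethylamino group present, methoxy and hydroxy cannot be told apart at this position. The other new step, a number 35 percentage points lower from compound 1 to compound 3 (beyond the scatter), comes with dimethylamino in place of phenoxy on an aromatic carbon, so the large gap seen earlier now traces to that swap and not to the methyl on the oxygen. No other data bear on these results, and what lies behind either step remains unexplained.

As far as these compounds go, it remains open whether a longer chain on that oxygen, such as an ethyl or benzyl group, or an amine in place of the oxygen, would also leave the read-out unmoved. From the compounds shown here alone, it is also open whether methoxy and hydroxy would match when phenoxy is present.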